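Swapping the pyrazole for a sulfonylphenyl group: working notes

The source may report more compounds than this note shows. Statements on the series, on what has been measured and on what is new or still open speak of the compounds shown alone.

Among the measured compounds shown here, in a functional assay on Pfeiffer cells (Homo sapiens) for cytotoxicity, read by scintillation counting and thymidine incorporation, with a stated time of 4 days (on this read-out lower numbers stand for stronger inhibition and higher numbers for weaker inhibition), compound 1 `COc1c([C@H](C)Nc2ncnc3[nH]cnc23)cc(Cl)c(C)c1-c1cnn(C)c1` gives 950 nM, and this is the only number available for the series, so it can be ranked against nothing. The one other tested structure, compound 2 `Cc1c(Cl)cc(C(C)Nc2ncnc3[nH]cnc23)c(-c2cccc(F)c2)c1-c1cnn(C)c1`, offers no comparison: its entry reads "not determined" (no result reported).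

The next compound to be read is compound 3 `COc1c([C@H](C)Nc2ncnc3[nH]cnc23)cc(Cl)c(C)c1-c1ccc(S(C)(=O)=O)cc1`. It keeps the core of compound 1 and carries 4-(methylsulfonyl)phenyl in place of 1-methyl-1H-pyrazol-4-yl on an aromatic carbon. The new group is larger, while the count of hydrogen-bond acceptors stays the same.

For the measured compounds named here, no step between measured compounds exists, so the data give no size for a swap of this kind. Going by the values given here, the only anchor is compound 1 at 950 nM, and no step beyond the usual scatter is expected in this assay, in either direction. The estimated change is a 1.1-fold lower number from compound 1 to compound 3 (0.02 log units; within the scatter), and this estimate is weakly supported. The range is kept wide for that reason.

For compound 3 the expected value is 900 nM, with an estimated range from 250 nM to 3200 nM.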

Compound 3, half-maximal inhibitory concentration: 3100 nM
Beside the measured number, compound 3's estimate is 3.4-fold (0.54 log units) below it; measured number inside the range.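

In this assay, among the compounds shown here, the position ortho to a methoxy group and ortho to a methyl group proves sensitive to the group it carries: 4-(methylsulfonyl)phenyl in place of 1-methyl-1H-pyrazol-4-yl gives a 3.3-fold higher number from compound 1 to compound 3 (0.51 log units; beyond the scatter), the first step that can be sized. The two groups have the same counts of hydrogen-bond donors and acceptors, so those counts do not separate them, whereas the entering group has the larger heavy-atom count, a six-membered ring of carbon only and the methylsulfonyl group, and this single step cannot tell these differences apart. No independent measurement bears on the origin of this step.

On these data alone, it remains open how an unsubstituted phenyl, a pyridine or a carboxylic acid on a phenyl ring would read at this position, and whether the methylsulfonyl group or the change of ring accounts for the higher number. For the compounds shown here, compound 2 cannot help to settle this, since its entry holds no number and no step to it can be read.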